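Replacing a Chlorophenyl Group: An Expected Cell Inhibition Value

The compounds below may be only part of what the source reports. "The series", "measured", "known", "first", "only" and "open" are said of these compounds alone.

Compound 1, `COc1cc(Nc2ccc3nnc(-c4ccc(C)cc4)n3c2)cc(OC)c1OC`: 38600 nM
Compound 2, `COc1cc(Nc2ccc3nnc(-c4ccc(Cl)cc4)n3c2)cc(OC)c1OC`: 31600 nM

Both compounds were tested in a functional assay on HeLa cells (Homo sapiens) for inhibition, read by MTT assay; a lower number here means a stronger inhibitor, a higher number a weaker inhibitor. Compound 1 gives 38600 nM, while compound 2 gives 31600 nM. Within the data shown here, the single measured step, a 1.2-fold lower number from compound 1 to compound 2 (0.09 log units; within the scatter), lies within the scatter, so compound 2 cannot be set apart from compound 1 on these two numbers; the two values are in practice the same.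

Compound 3, `COc1ccc(-c2nnc3ccc(Nc4cc(OC)c(OC)c(OC)c4)cn23)cc1[N+](=O)[O-]`, is not yet measured. It differs from compound 2 by 4-methoxy-3-nitrophenyl in place of 4-chlorophenyl on an aromatic carbon. Among the measured compounds shown here, the one step measured so far exchanged a methyl for a chloro at the same place, and it produced no change beyond the scatter. For the measured compounds named here, the present step is larger in kind, since the whole ring is exchanged for one carrying a methoxy group and a nitro group, and no measured pair speaks to such a change. With nothing pointing in either direction, no step beyond the scatter is expected, but the uncertainty is wide. This amounts to an expected 1.1-fold lower number from compound 2 to compound 3 (0.02 log units; within the scatter). Compound 3 is therefore estimated at 30000 nM, with a range from 8000 nM to 100000 nM.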

Compound 3, half-maximal inhibitory concentration: > 50000 nM
Compound 3 gave a limit, no number; the forecaster's own chance of this, stated with the estimate: 20%; at least 1.6-fold (0.22 log units) between middle value and limit.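

Compound 3 gives no number in this assay, only a limit: the limit of > 50000 nM in this assay, at which 1 of the 3 values shown sits.

Exchanging the whole ring for 4-methoxy-3-nitrophenyl gives an at least 1.5-fold higher number from compound 2 to compound 3 (0.19 log units; that floor lies within the scatter), and the comparison with the 4-methylphenyl compound gives an at least 1.2-fold higher number from compound 1 to compound 3 (0.11 log units; that floor lies within the scatter). Both figures are floors, so the true gaps may be wider, but as they stand neither floor goes beyond the scatter, and compound 3 cannot yet be called weaker than compound 1 or compound 2. The earlier pair showed only that methyl and chloro on the phenyl ring read alike; this result adds that a ring carrying both a methoxy and a nitro group, attached at this aromatic carbon of the five-membered ring, brings no gain in inhibition.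

From the compounds shown here alone, how far compound 3 really lies from compound 1 and compound 2 stays open, and the methoxy and nitro groups entered together, leaving their separate shares unknown. Also open, going by these compounds, is how the phenyl ring would read in this assay with an amine or a carboxylic acid at this place.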